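A few compounds are considered here, and "the series" means these few. Any claim that something is new, unique, unknown or untested is made for them only; others in the source may bear on it.

Compound 1 `O=c1nc(N2CCN(NC3CCCCC3)CC2)sc2c([N+](=O)[O-])cc(C(F)(F)F)cc12`: in an ADME assay on Vero cells (Chlorocebus sabaeus) for cytotoxicity, read by MTT assay, with a stated time of 72 h (on this read-out lower numbers stand for higher toxicity in this test and higher numbers for lower toxicity in this test), compound 1 gives > 64 ug/mL, which is a limit of the test rather than a number.
Compound 2 `O=c1nc(N2CCN(NCc3ccc(OC(F)(F)F)cc3)CC2)sc2c([N+](=O)[O-])cc(C(F)(F)F)cc12`: in this assay compound 2 gives > 64 ug/mL, also a limit.
Compound 3 `O=c1nc(N2CCN(NCc3cccc(C(F)(F)F)c3)CC2)sc2c([N+](=O)[O-])cc(C(F)(F)F)cc12`: in this assay compound 3 gives > 64 ug/mL, again a limit.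

Compound 3 therefore stands exactly where the other two measured compounds stand, at the limit of > 64 ug/mL in this assay, at which 3 of the 3 values shown sit. The three measured steps, a step that the two limits leave unreadable from compound 1 to compound 2, a step that the two limits leave unreadable from compound 1 to compound 3 and a step that the two limits leave unreadable from compound 2 to compound 3, each have both ends at a limit, so no size and no direction can be read from any of them. Compound 4 `O=c1nc(N2CCN(NCc3ccc(F)cc3)CC2)sc2c([N+](=O)[O-])cc(C(F)(F)F)cc12` differs from compound 3 by 4-fluorophenyl in place of 3-(trifluoromethyl)phenyl on a saturated chain carbon bound to an amine nitrogen. Among the compounds with values here, the steps that bear on this change are those that swap the group carried by the same amine nitrogen, and every one of them was unreadable. Nothing in the measured data points toward a step of any size in this assay, in either direction. The expectation is that compound 4 gives 64 ug/mL, within a range of 32 ug/mL to 128 ug/mL. The step of a number no higher from compound 3 to compound 4 (the limit leaves the size open) is thus expected to be none beyond the scatter, with the result most likely reported again as a limit.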

Compound 4, half-maximal cytotoxic concentration: > 64 ug/mL
Compound 4: no number, only a limit; the forecaster's own chance of this, stated with the estimate: 80%; the middle value sits exactly at the limit.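

No step from compound 1, compound 2 or compound 3 to compound 4 can be read, because both ends of each step are limits of this assay rather than numbers: the limit of > 64 ug/mL in this assay, at which 4 of the 4 values shown sit.
The compounds shown leave open whether swapping the group on the amine nitrogen changes the result in this assay at all, and in which direction and by how much.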